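Methyl on the N-phenyl: an untested step from compound 3

The compounds below may be only part of what the source reports. "The series", "measured", "known", "first", "only" and "open" are said of these compounds alone.

Compound 1 `CCc1ccc(NC(=O)c2cccc(/C=C3\CC(=O)N(c4ccccc4)C3=O)c2)cc1` in an ADME assay on HCT-116 cells (Homo sapiens) for cytotoxicity, read by MTT assay, with a stated time of 72 h; on this read-out higher numbers stand for weaker inhibition and lower numbers for stronger inhibition: > 100000 nM (a limit of the assay).
Compound 2 `Cc1cccc(NC(=O)c2cccc(/C=C3\CC(=O)N(c4ccccc4)C3=O)c2)c1` in this assay: > 100000 nM (a limit of the assay).
Compound 3 `COc1ccc(NC(=O)c2cccc(/C=C3\CC(=O)N(c4ccccc4)C3=O)c2)cc1` in this assay: > 100000 nM (a limit of the assay).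

Compound 3 stands where every measured value stands, at the limit of > 100000 nM in this assay, at which 3 of the 3 values shown sit. Its value is a limit, not a number. Compound 4 `COc1ccc(NC(=O)c2cccc(/C=C3\CC(=O)N(c4ccc(C)cc4)C3=O)c2)cc1` differs from it by methyl in place of hydrogen on an aromatic carbon; the step is methyl in place of hydrogen on an aromatic carbon of a six-membered aromatic ring of carbon only.

For the measured compounds named here, none of the measured steps touches this ring. The steps a step that the two limits leave unreadable from compound 1 to compound 2, a step that the two limits leave unreadable from compound 1 to compound 3 and a step that the two limits leave unreadable from compound 2 to compound 3 all change the other aryl amide and all remain unreadable, as both ends sit at the same limit. They therefore offer no measured size for the change from compound 3 to compound 4 and no direction.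

With three compounds of the shared core all at the limit, the expectation for compound 4 is that it also gives only a limit in this assay, and the expected step of a number no higher from compound 3 to compound 4 (the limit leaves the size open) is none beyond the scatter. The estimate for compound 4 is 100000 nM, within 30000 nM to 300000 nM.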

Compound 4, half-maximal inhibitory concentration: > 100000 nM
Compound 4 ended at the assay's limit; the forecaster's own chance of this, stated with the estimate: 80%; the middle value sits exactly at the limit.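

In this assay compound 4 gives > 100000 nM, which is a limit of the assay. Compound 3 also stands at a limit, so no step can be read between compound 3 and compound 4: the limit of > 100000 nM in this assay, at which 4 of the 4 values shown sit.

The compounds shown leave open what concentration would give half-maximal inhibition for any of them, and what methyl in place of hydrogen changes.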